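Replacing Phenoxy with Benzofuranyl on the Shared Core

A few compounds are considered here, and "the series" means these few. Any claim that something is new, unique, unknown or untested is made for them only; others in the source may bear on it.

Compound 1 `Cc1ccccc1-n1nc(C)c2c1NC(=O)[C@H](C)S[C@@H]2c1ccc(Oc2ccccc2)cc1` is the point of departure. In an assay on isolated protein for agonist activity at Bile acid receptor (Homo sapiens), read by AlphaScreen, with a stated time of 30 min (on this read-out lower numbers stand for an effect already at smaller amounts and higher numbers for an effect only at larger amounts of compound), compound 1 gives 1300 nM, the lowest of the three numbers in hand, though neither neighbour is separated from it beyond the scatter. Compound 2 `Cc1nn(-c2ccccc2C(C)C)c2c1[C@@H](c1ccc(Oc3ccccc3)cc1)S[C@@H](C)C(=O)N2` gives 1900 nM in this assay, and the step of a 1.5-fold higher number from compound 1 to compound 2 (0.16 log units; within the scatter) stays within the scatter. Compound 3 `COc1ccc(Oc2ccc([C@H]3S[C@@H](C)C(=O)Nc4c3c(C)nn4-c3ccccc3C)cc2)cc1` gives 2200 nM in this assay, and the step of a 1.7-fold higher number from compound 1 to compound 3 (0.23 log units; within the scatter) likewise stays within the scatter. Compound 4 `Cc1ccccc1-n1nc(C)c2c1NC(=O)[C@H](C)S[C@@H]2c1ccc(-c2cc3ccccc3o2)cc1` has not yet been measured. It differs from compound 1 in one place: 1-benzofuran-2-yl in place of phenoxy on an aromatic carbon. Neither measured step touches this position; both alter other parts of the molecule, and both were small. Within the data shown here, there is thus no direct precedent for swapping phenoxy for 1-benzofuran-2-yl, and the wide spread of possible outcomes is acknowledged. Compound 4 is expected to give about 1500 nM in this assay, within a range of 450 nM to 5000 nM. The estimated step of a 1.2-fold higher number from compound 1 to compound 4 (0.06 log units; within the scatter) is therefore expected to lie within the scatter, with direction uncertain.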

Compound 4, half-maximal effective concentration: 1500 nM
Estimate against measurement, compound 4: no gap at the digits printed; the range from low to high includes it.
By their numbers in this assay, from the lowest: compounds 1, 4, 2 and 3 (each within the scatter of the next).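

Swapping phenoxy for 1-benzofuran-2-yl, on the aromatic carbon para to a large group, is the first change shown at this position, and in this assay it gives a 1.2-fold higher number from compound 1 to compound 4 (0.06 log units; within the scatter). The same group in place of 4-methoxyphenoxy gives a 1.5-fold lower number from compound 3 to compound 4 (0.17 log units; within the scatter), so compounds 1, 3 and 4 cannot be told apart in this assay, even though the group at this position differs among all three. Nothing available explains why these changes leave the number within the scatter.

As far as these compounds go, it remains open whether an amine or a carboxylic acid at this position would shift the number beyond the scatter. A methyl group or a longer alkyl chain there is equally untested among the compounds shown, so how far this position accepts change is still unknown.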